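The source may report more compounds than this note shows. Statements on the series, on what has been measured and on what is new or still open speak of the compounds shown alone.

Compound 1 `CN(C)c1ccc(-c2ccc3[nH]c(=O)nc(-c4ccccc4)c3c2)cn1`: > 50000 nM
Compound 2 `O=c1nc(-c2ccccc2)c2cc(-c3ccccc3)ccc2[nH]1`: > 50000 nM

In an ADME assay on THP-1 cells (Homo sapiens) for cytotoxicity, read by MTT assay, with a stated time of 72 h (on this read-out higher numbers stand for an effect only at larger amounts of compound and lower numbers for an effect already at smaller amounts), compound 1 reaches only the limit of the assay, reported as > 50000 nM. In this assay compound 2 likewise gives only a limit, > 50000 nM. Compound 2 thus stands together with compound 1 at the limit of > 50000 nM in this assay, at which 2 of the 2 values shown sit; no number separates the two. Compound 3 `Cn1nccc1-c1ccc2[nH]c(=O)nc(-c3ccccc3)c2c1` carries 1-methyl-1H-pyrazol-5-yl in place of phenyl on an aromatic carbon. With both measured compounds at the limit, the step of a number no higher from compound 2 to compound 3 (the limit leaves the size open) is expected to be none beyond the scatter. Compound 3 is therefore estimated at about 50000 nM, between 20000 nM and 100000 nM, most likely reported again only as a limit.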

Compound 3, half-maximal effective concentration: > 50000 nM
Compound 3 ended at the assay's limit (the forecaster's own chance of this, stated with the estimate: 75%); the middle value lies on the limit itself.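

Compound 2 and compound 3 both give only a limit in this assay, so no step between them can be read: the limit of > 50000 nM in this assay, at which 3 of the 3 values shown sit.

The compounds shown leave open whether 1-methyl-1H-pyrazol-5-yl in place of phenyl changes this read-out at all.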